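The source may report more compounds than this note shows. Statements on the series, on what has been measured and on what is new or still open speak of the compounds shown alone.

Measured compounds:
compound 1 `COc1ccc(-c2[nH]c3ccccc3c2/C=C(\C#N)S(=O)(=O)c2ccccc2)cc1`, 299 nM
compound 2 `COc1ccc(-c2[nH]c3ccc(OC)cc3c2/C=C(\C#N)S(=O)(=O)c2ccccc2)cc1`, 510 nM

These two numbers come from a functional assay on SF-539 cells (Homo sapiens) for inhibition, read by sulforhodamine B assay, with a stated time of 48 h; a higher number here means a weaker inhibitor of growth, a lower number a stronger inhibitor of growth. Compound 2 has the highest of the two numbers, with compound 1 nearest: a 1.7-fold higher number from compound 1 to compound 2 (0.23 log units; within the scatter). Compound 3 `COc1ccc2[nH]c(-c3ccccc3)c(/C=C(\C#N)S(=O)(=O)c3ccccc3)c2c1` differs from compound 2 by hydrogen in place of methoxy on an aromatic carbon. Within the data shown here, the only measured step, from compound 1 to compound 2, changes a methoxy at a different place and stays within the scatter, so it bears on this step only loosely. Compound 3 is therefore expected to show no step beyond the scatter, a 1.0-fold lower number from compound 2 to compound 3 (0.01 log units; within the scatter). The estimate for compound 3 is 500 nM, with a range from 200 nM to 1300 nM.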

Compound 3, concentration for 50% growth inhibition: 5500 nM
For compound 3 the middle estimate is 11-fold (1.04 log units) below the measured one; measured number outside the range, above it.
By their numbers in this assay, from the lowest: compounds 1 and 2 (each within the scatter of the next); then compound 3.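

Going from 4-methoxyphenyl to phenyl gives an 11-fold higher number from compound 2 to compound 3 (1.03 log units; beyond the scatter) in this assay and so shows that the methoxy para to a large group counts for much in this series. The methoxy changed earlier, at a different place, gave only a 1.7-fold higher number from compound 1 to compound 2 (0.23 log units; within the scatter) and stayed within the scatter. No measurement shown offers an explanation for this loss of growth inhibition.

Still open, on these data alone, is whether a hydroxyl, a fluorine or an ethoxy at this place would keep the number close to that of compound 2.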